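A few compounds are considered here, and "the series" means these few. Any claim that something is new, unique, unknown or untested is made for them only; others in the source may bear on it.

Compound 1 `C=CC(=O)Nc1cccc(Nc2ncnc(Nc3ccc(-c4ccc(C)nc4)cc3)n2)c1`, compound 2 `C=CC(=O)Nc1cccc(Nc2ncnc(Nc3ccc(-c4ccc(Cl)nc4)cc3)n2)c1` and compound 3 `C=CC(=O)Nc1cccc(Nc2ncnc(Nc3ccc(-c4cccnc4)cc3)n2)c1` share one core and differ only on the ring that sits on the outer aniline. In a functional assay on Raji cells (Homo sapiens) for antiproliferative activity, read by CCK-8 assay, with a stated time of 24 h (a higher number here means a weaker inhibitor, a lower number a stronger inhibitor), compound 1 gives 13800 nM; compound 3 gives 12400 nM; for compound 2 the record holds only "not determined" (no result reported). Within the data shown here, the single one-point step, a 1.1-fold lower number from compound 1 to compound 3 (0.05 log units; within the scatter), is within the scatter, so compound 3 stands at the lower of two numbers that cannot be told apart.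

Compound 4 `C=CC(=O)Nc1cccc(Nc2ncnc(Nc3ccc(OC)cc3)n2)c1` takes the next step: methoxy in place of pyridin-3-yl on an aromatic carbon. Among the measured compounds shown here, no measured step touches this change; the one step known concerns hydrogen in place of methyl on the pyridin-3-yl ring, not the loss of that ring, and it was flat. With nothing to push either way, compound 3 is the only anchor, and the estimated step of a 1.2-fold higher number from compound 3 to compound 4 (0.08 log units; within the scatter) is expected to stay near the scatter, with a wide range because the whole ring leaves. Compound 4 is therefore expected to give about 15000 nM, between 5000 nM and 50000 nM.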

Compound 4, half-maximal inhibitory concentration: 14500 nM
For compound 4 the middle estimate is 1.0-fold (0.01 log units) above the measured one; low and high end bracket the measured number.
By their numbers in this assay, from the lowest: compounds 3, 1 and 4 (each within the scatter of the next).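

In this assay, the step that removes the whole ring, a 1.2-fold higher number from compound 3 to compound 4 (0.07 log units; within the scatter), stays within the scatter, and so does the step from the methyl-bearing ring, a 1.1-fold higher number from compound 1 to compound 4 (0.02 log units; within the scatter). The earlier compounds shown here had changed only a hydrogen or methyl on the pyridin-3-yl ring, whereas here the ring itself gives way to methoxy, a group of 2 heavy atoms with no ring, and the number does not respond on this aromatic carbon, para to a large group. Nothing measured here offers an explanation for this flatness.

Going by these compounds, whether an amine, a carboxylic acid or a longer alkoxy chain on this carbon would move the number beyond the scatter remains open. No step shown so far leaves the scatter, so it is also unknown whether this position can influence the number at all.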